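From cyclopropyl to 4-propylphenyl on the amine nitrogen

A few compounds are considered here, and "the series" means these few. Any claim that something is new, unique, unknown or untested is made for them only; others in the source may bear on it.

Compound 1 `O=C1C(Nc2ccccc2)=CC(=O)c2c1nc1n2[C@H]2OC[C@@H](O)[C@H]2OC1`: 1830 nM
Compound 2 `O=C1C(NC2CC2)=CC(=O)c2c1nc1n2[C@H]2OC[C@@H](O)[C@H]2OC1`: > 4000 nM (a limit, not a number)

In a functional assay on MGC-803 cells (Homo sapiens) for inhibition, read by sulforhodamine B assay (on this read-out lower numbers stand for stronger inhibition and higher numbers for weaker inhibition), compound 2 stands at the limit of > 4000 nM in this assay, at which 1 of the 2 values shown sits. Compound 3 `CCCc1ccc(NC2=CC(=O)c3c(nc4n3[C@H]3OC[C@@H](O)[C@H]3OC4)C2=O)cc1` differs from compound 2 by 4-propylphenyl in place of cyclopropyl on an amine nitrogen. For the measured compounds named here, the only measured step bearing on this is an at least 2.1-fold higher number from compound 1 to compound 2 (0.33 log units; beyond the scatter), where cyclopropyl took the place of phenyl. Compound 3 again carries a six-membered aromatic ring there, so a move to a lower number is expected, and the expected size is an at least 2.6-fold lower number from compound 2 to compound 3 (0.42 log units; beyond the scatter). Compound 3 is estimated at 1500 nM, with an expected range of 600 nM to 4000 nM.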

Compound 3, half-maximal inhibitory concentration: 1920 nM
Estimate against measurement, compound 3: 1.3-fold (0.11 log units) below; measured number inside the range.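

In this assay, the return of a six-membered aromatic ring on the amine nitrogen gives an at least 2.0-fold lower number from compound 2 to compound 3 (0.31 log units; beyond the scatter), so the earlier step away from phenyl is now matched by a step in the opposite direction. Compound 2 holds a limit, not a number: the limit of > 4000 nM in this assay, at which 1 of the 3 values shown sits. Propyl in place of hydrogen on an aromatic carbon gives a 1.0-fold higher number from compound 1 to compound 3 (0.02 log units; within the scatter), so this chain leaves the read-out unchanged.

On these data alone, whether a longer chain, an amine or a carboxylic acid in place of the propyl would shift the number stays open. So does how far compound 2 actually lies from compound 3.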